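The source may report more compounds than this note shows. Statements on the series, on what has been measured and on what is new or still open speak of the compounds shown alone.

Compound 1 `CN1CCC[C@H]1COc1cncc(C#CC(C)(C)O)c1`: 2.9 nM
Compound 2 `CCCCC#Cc1cncc(OC[C@@H]2CCCN2C)c1`: 1.4 nM
Compound 3 `C#Cc1cncc(OC[C@@H]2CCCN2C)c1`: 1.6 nM

In an assay on a protein complex for binding affinity to Neuronal acetylcholine receptor; alpha4/beta2 (Rattus norvegicus) (on this read-out higher numbers stand for weaker inhibition and lower numbers for stronger inhibition), compound 3 stands second highest of the three numbers; compound 2 is nearest to it and compound 1 furthest, and both gaps fall within the scatter, so the three compounds cannot be ordered against one another. Compound 4 `CN1CCC[C@H]1COc1cncc(C#CCCCCO)c1` has not yet been measured. It differs from compound 3 by 4-hydroxybutyl in place of hydrogen on a triple-bonded carbon. Within the data shown here, two measured steps bear on this change. The step of a 1.1-fold higher number from compound 2 to compound 3 (0.06 log units; within the scatter) shows that a butyl chain on the triple-bonded carbon makes no difference beyond the scatter, and the step of a 1.8-fold lower number from compound 1 to compound 3 (0.26 log units; within the scatter) shows the same for a 1-hydroxy-1-methylethyl group, which carries a hydroxyl as the incoming 4-hydroxybutyl does. Among the measured compounds shown here, the only step beyond the scatter, a 2.1-fold lower number from compound 1 to compound 2 (0.32 log units; beyond the scatter), is modest. Neither a chain nor a hydroxyl on this carbon has moved the number in this assay by more than the scatter, so for compound 4 a step of about a 1.1-fold higher number from compound 3 to compound 4 (0.03 log units; within the scatter) is expected, which is none beyond the scatter. Compound 4 is therefore estimated at 1.7 nM in this assay, with a range from 0.6 nM to 4.5 nM.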

Compound 4, inhibition constant: 0.85 nM
Compound 4: middle estimate off by 2.0-fold (0.30 log units), on the high side, within the range that was stated.
By their numbers in this assay, from the lowest: compounds 4, 2, 3 and 1 (each within the scatter of the next, the first and the last beyond it).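

In this assay the full 4-hydroxybutyl chain on the triple-bonded carbon stays level with hydrogen (a 1.9-fold lower number from compound 3 to compound 4 (0.27 log units; within the scatter)), and adding the hydroxy to the saturated chain, four bonds along from that carbon, leaves it level with the plain butyl chain (a 1.6-fold lower number from compound 2 to compound 4 (0.22 log units; within the scatter)), so this position has now taken a chain with a hydroxy as well as one without. Among these compounds, the first comparison of two hydroxyl-bearing groups on this carbon gives a modest step beyond the scatter (a 3.4-fold lower number from compound 1 to compound 4 (0.53 log units; beyond the scatter)), which shows that carrying a hydroxyl does not by itself set the number, although compound 1 remains within the scatter of compound 3, which has only hydrogen here. Nothing given here accounts for these steps.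

The compounds shown leave open whether a longer chain, or an amine or a carboxylic acid in place of the hydroxy, would also stay level with hydrogen at this position. They also leave open whether a chain carrying the hydroxy closer to the triple-bonded carbon, but without the two methyl groups of 1-hydroxy-1-methylethyl, would fall with compound 1 or with compound 4.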